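Carbamoylphenyl in Place of Fluorophenyl: Solubility Outlook

This account rests on a few compounds, and the source may have more. Where it says the series, first, only, none or still open, it means among the compounds named here.

Compound 1 `Cc1noc(-c2nc(C)c3c(c2N)C(=O)N(CC2CCNCC2)C3=O)n1`: 160000 nM
Compound 2 `Cc1noc(-c2nc(C)c3c(c2N)C(=O)N(Cc2ccc(Cl)cc2)C3=O)n1`: < 5000 nM
Compound 3 `Cc1noc(-c2nc(C)c3c(c2N)C(=O)N(Cc2cccc(F)c2)C3=O)n1`: < 5000 nM

In a physicochemical assay for solubility, using the shake flask method, in simulated intestinal fluid, measured as kinetic solubility, with a stated time of 2 h, at 25 degrees C, at pH 6.5 (a higher number here means a more soluble compound, a lower number a less soluble compound), compound 3 gives only a limit, < 5000 nM, so its true number is not known. Compound 2 also sits at that limit, (the limit of < 5000 nM in this assay, at which 2 of the 3 values shown sit). Compound 4 `Cc1noc(-c2nc(C)c3c(c2N)C(=O)N(Cc2ccc(C(N)=O)cc2)C3=O)n1` differs from compound 3 by 4-carbamoylphenyl in place of 3-fluorophenyl on a saturated chain carbon bound to an amide-type nitrogen in a ring; the entering group carries one hydrogen-bond donor and one acceptor, which the leaving group lacks. Among the compounds with values here, the steps that bear on this are an at least 32-fold lower number from compound 1 to compound 2 (1.50 log units; beyond the scatter) and an at least 32-fold lower number from compound 1 to compound 3 (1.50 log units; beyond the scatter), both large, whereas a step that the two limits leave unreadable from compound 2 to compound 3. A moderate rise in this assay is expected, though the limit on compound 3 makes its size uncertain. Compound 4 is therefore expected to give 15000 nM, within 3000 nM to 60000 nM. That estimate means a step of an at least 3.0-fold higher number from compound 3 to compound 4 (0.47 log units; beyond the scatter).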

Compound 4, solubility: < 5000 nM
Compound 4: no number, only a limit (the forecaster's own chance of this, stated with the estimate: 35%); at least 3.0-fold (0.47 log units) between middle value and limit.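

In this assay compound 4 gives < 5000 nM as a limit and not a number. Within the data shown here, the steps from compound 2 and compound 3 to compound 4 cannot be read, while an at least 32-fold lower number from compound 1 to compound 4 (1.50 log units; beyond the scatter) is large, as the earlier steps from compound 1 were. At this saturated chain carbon, the hydrogen-bond donor and acceptor of 4-carbamoylphenyl therefore do not bring compound 4 clear of the limit shared by the phenyl compounds: the limit of < 5000 nM in this assay, at which 3 of the 4 values shown sit.

As far as these compounds go, how far compound 2, compound 3 and compound 4 differ under that limit stays open. So does whether an aminomethyl group or a carboxylic acid on the phenyl ring would give a readable number.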